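Dropping Two Chlorines from a Weak Cytotoxic Ester

The source may report more compounds than this note shows. Statements on the series, on what has been measured and on what is new or still open speak of the compounds shown alone.

Compound 1 `COCOc1cc(/C=C/C(=O)OCC(=O)Nc2ccc(Cl)cc2)ccc1OCc1ccccc1`.
In a functional assay on LS174T cells (Homo sapiens) for cytotoxicity, read by MTT assay, with a stated time of 72 h (a lower number here means a stronger inhibitor, a higher number a weaker inhibitor), compound 1 reaches only the limit of the assay, > 200000 nM.
Compound 2 `COc1ccc(NC(=O)COC(=O)/C=C/c2cc(OC)c(OCc3ccc(Cl)c(Cl)c3)c(OC)c2)cc1`.
In this assay compound 2 likewise reaches only the limit of the assay, > 200000 nM.

Compound 2 therefore stands at the limit, the point where both measured values sit (the limit of > 200000 nM in this assay, at which 2 of the 2 values shown sit). Its value and that of compound 1 show nothing that separates the two.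

Compound 3 `COc1ccc(NC(=O)COC(=O)/C=C/c2cc(OC)c(OCc3ccccc3)c(OC)c2)cc1` differs from compound 2 in one place: phenyl in place of 3,4-dichlorophenyl on a saturated chain carbon bound to an oxygen on an aromatic ring. For the measured compounds named here, no measured pair shows a comparable change, so its effect is unknown here. Both measured compounds sit at the limit, so in this assay the expected step is a step that the limit leaves unreadable from compound 2 to compound 3, most likely none beyond the scatter. Compound 3 is expected to remain at or near the limit, estimated at 250000 nM with a range from 100000 nM to 600000 nM.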

Compound 3, half-maximal inhibitory concentration: > 200000 nM
Compound 3 gave a limit, no number; the forecaster's own chance of this, stated with the estimate: 85%; the middle value does not contradict the limit.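

Compound 2 and compound 3 both give only a limit in this assay, not a number, so no step between them can be read: the limit of > 200000 nM in this assay, at which 3 of the 3 values shown sit.

As far as these compounds go, whether phenyl and 3,4-dichlorophenyl differ at all in their effect on cytotoxicity stays open, as does what would bring these esters to a measurable value.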